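The compounds below may be only part of what the source reports. "The series", "measured", "known", "first", "only" and "open" are said of these compounds alone.

Measured compounds:
Compound 1, `C=CCN(CC[C@H](N)C(=O)O)C[C@H]1O[C@@H](n2cnc3c(N)ncnc32)[C@H](O)[C@@H]1O`: in an assay for inhibition of tRNA (cytosine(38)-C(5))-methyltransferase (Homo sapiens), with a stated time of 5 min, tested at 100 uM (on this read-out higher numbers stand for more inhibition at the one concentration tested (going by the name of the read-out) and lower numbers for less inhibition), compound 1 gives 53.9%.
Compound 2, `CCC#CCN(CC[C@H](N)C(=O)O)C[C@H]1O[C@@H](n2cnc3c(N)ncnc32)[C@H](O)[C@@H]1O`: in this assay compound 2 gives 62.8%.

Compound 2 holds the higher of the two numbers, yet the step of a number 8.9 percentage points higher from compound 1 to compound 2 (within the scatter) stays within the scatter, so the two compounds cannot be ranked on what is shown. Compound 3, `C#CCCN(CC[C@H](N)C(=O)O)C[C@H]1O[C@@H](n2cnc3c(N)ncnc32)[C@H](O)[C@@H]1O`, follows from compound 2 by one change: propargyl in place of but-1-yn-1-yl on a saturated chain carbon bound to an amine nitrogen. Within the data shown here, the only measured step, from compound 1 to compound 2, also reshaped the group on this same chain carbon and moved the inhibition by no more than the scatter; it bears on the present step only loosely, since there the unsaturated chain grew rather than shrank. With a single step of that kind and no other guide, the account expects for compound 3 a step of a number 6.8 percentage points lower from compound 2 to compound 3 (within the scatter) in this assay, that is, nothing beyond the scatter. Compound 3 is therefore estimated at 56%, with a range from 40% to 70%.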

Compound 3, a percentage reported as inhibition, at one concentration (the size of the read-out at that concentration, not a potency): 30.2%
Estimate against measurement, compound 3: 25.8 percentage points above, and the stated range ends above it.
By their numbers in this assay, from the lowest: compound 3; then compounds 1 and 2 (each within the scatter of the next).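

In this assay the group on this saturated chain carbon bound to an amine nitrogen can move the inhibition beyond the scatter, which the earlier step did not show. Both groups carry a triple bond outside aromatic rings, and the change from 4 heavy atoms to 3, read one bond further out as pent-2-yn-1-yl to but-3-yn-1-yl, still gives a number 32.6 percentage points lower from compound 2 to compound 3 (beyond the scatter) in this read-out, so a triple bond alone does not set the level of inhibition. Propargyl in place of vinyl gives a number 23.7 percentage points lower from compound 1 to compound 3 (beyond the scatter) as well, leaving compound 3 the lowest of the three, and nothing at hand accounts for this fall. The compounds shown leave open how a longer chain carrying a triple bond would read at this place. They also leave open how a saturated propyl chain, or a chain ending in an amine or a carboxylic acid, would compare.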